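Ring amine substitution: from compound 1 to compound 3

The source may report more compounds than this note shows. Statements on the series, on what has been measured and on what is new or still open speak of the compounds shown alone.

For the measured compounds named here, compound 1 `NC(=O)c1c(NC(=O)c2ccccc2Cl)sc2c1CCN(Cc1ccccc1F)C2` gives 12900 nM in a functional assay on MKN-74 cells (Homo sapiens) for antiproliferative activity, with a stated time of 24 h (on this read-out lower numbers stand for stronger inhibition and higher numbers for weaker inhibition), and stands lowest of the two numbers so far, while compound 2 `NC(=O)c1c(NC(=O)c2ccc(C(F)(F)F)cc2)sc2c1CCN(Cc1ccccc1F)C2` gives 26900 nM. Going by the values given here, the single measured step, a 2.1-fold higher number from compound 1 to compound 2 (0.32 log units; beyond the scatter), concerns the group on the carbonyl carbon and not the amine nitrogen in a ring where compound 3 `NC(=O)c1c(NC(=O)c2ccccc2Cl)sc2c1CCN(C(=S)Nc1ccccc1)C2` is changed: a group of 9 heavy atoms (7 carbon, 1 nitrogen, 1 sulfur; one six-membered aromatic ring of carbon only) in place of a group of 8 heavy atoms (7 carbon, 1 fluorine; one six-membered aromatic ring of carbon only), on an amine nitrogen in a ring. Among the compounds with values here, no measured step bears on this change, so a step within the scatter is expected, a 1.0-fold higher number from compound 1 to compound 3 (0.00 log units; within the scatter), with no fixed direction. Compound 3 is therefore estimated at 13000 nM, within a range from 4500 nM to 40000 nM.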

Compound 3, half-maximal inhibitory concentration: 15600 nM
For compound 3 the middle estimate is 1.2-fold (0.08 log units) below the measured one, and the stated range covers the measured number.
By their numbers in this assay, from the lowest: compounds 1, 3 and 2 (each within the scatter of the next, the first and the last beyond it).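

In this assay the exchange of 2-fluorobenzyl for a group with a hydrogen-bond donor, a hydrogen-bond acceptor and a double bond outside aromatic rings, on the amine nitrogen in a ring, gives only a 1.2-fold higher number from compound 1 to compound 3 (0.08 log units; within the scatter) and so separates the two compounds by no more than the scatter. For the compounds shown here, this is the first reading at this position, as the earlier step concerned the group on the carbonyl carbon. No available measurement accounts for this result.

Still open, going by these compounds, is how this nitrogen responds to a much smaller group such as methyl, or to a chain ending in a carboxylic acid. Also open, on these data alone, is whether the same exchange gives a similar result with 4-(trifluoromethyl)phenyl on the carbonyl carbon.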